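Adding a Third Methoxy Group on the Way to Compound 4

The compounds below may be only part of what the source reports. "The series", "measured", "known", "first", "only" and "open" are said of these compounds alone.

Measured compounds in a functional assay on LNCaP C4-2 cells (Homo sapiens) for inhibition, read by MTT assay, with a stated time of 48 h; on this read-out lower numbers stand for stronger inhibition and higher numbers for weaker inhibition:
- compound 1, `Cc1[nH]c2ccccc2c1C1CC(c2ccncc2)=NO1`: compound 1 gives 45100 nM
- compound 2, `COc1ccc(C2=NOC(c3c[nH]c4ccccc34)C2)cc1OC`: compound 2 gives 65500 nM
- compound 3, `Fc1ccc2c(C3CC(c4ccncc4)=NO3)c[nH]c2c1`: compound 3 gives 8000 nM

Of the three numbers seen so far, compound 2 stands at the highest. Its nearest neighbour is compound 1, whose number lies within the scatter of that of compound 2, so nothing of order can be read between the two. Compound 3 is furthest away, with a number that lies well beyond the scatter below compound 2.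

Compound 4, `COc1cc(C2=NOC(c3c[nH]c4ccccc34)C2)cc(OC)c1OC`, has not been measured. It differs from compound 2 in one place: methoxy in place of hydrogen on an aromatic carbon. Going by the values given here, no step between two measured compounds matches this change, so there is nothing of the same kind to lean on. The expectation for the step from compound 2 to compound 4 in this assay is therefore one of no clear size in either direction, with a 1.3-fold lower number from compound 2 to compound 4 (0.12 log units; within the scatter) taken as lying inside the scatter of repeated measurements. Compound 4 is thus expected to give about 50000 nM, with a range from 18000 nM to 140000 nM.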

Compound 4, half-maximal inhibitory concentration: 5000 nM
The estimate for compound 4 lay 10-fold (1.00 log units) above the measured number; the whole stated range lies above it.
By their numbers in this assay, from the lowest: compounds 4 and 3 (each within the scatter of the next); then compounds 1 and 2 (each within the scatter of the next).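

In this assay, methoxy in place of hydrogen on an aromatic carbon, ortho to a methoxy group and meta to a large group, gives a 13-fold lower number from compound 2 to compound 4 (1.12 log units; beyond the scatter). Going by these compounds alone, this is the first change in a single place that can be read, and it shows that the number responds strongly to substitution at this position of the ring. Nothing measured here accounts for the size of this step.

On these data alone, it remains open whether the step is specific to methoxy or would also appear with a hydroxyl group, a fluorine atom, an amine or a longer ethoxy chain at the same position. As far as these compounds go, it also remains open whether the step depends on the other methoxy groups of compound 4.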